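The source may report more compounds than this note shows. Statements on the series, on what has been measured and on what is new or still open speak of the compounds shown alone.

The account opens with compound 1 `Cc1ccc(C(=O)NNC(=S)Nc2csc(-c3ccccc3)c2)cc1` and compound 2 `Cc1ccc(C(=O)NNC(=S)Nc2csc(-c3ccc(C)cc3)c2)cc1`, which share one core and differ only by methyl in place of hydrogen on an aromatic carbon. In a functional assay on SK-MEL-28 cells (Homo sapiens) for inhibition, read by colorimetric assay and MTT assay, with a stated time of 72 h (a higher number here means a weaker inhibitor, a lower number a stronger inhibitor), compound 1 gives 40000 nM, and compound 2 gives 44000 nM, so the change brings a 1.1-fold higher number from compound 1 to compound 2 (0.04 log units; within the scatter). Compound 3 `Oc1ccc(-c2nnc(Nc3csc(-c4ccccc4)c3)s2)cc1` rests on a second core; how it differs from the core of compound 1 is not broken down here. In this assay compound 3 gives 57000 nM, and its gaps to compound 1 and to compound 2 both lie within the scatter, so the three numbers cannot be set apart from one another. Compound 4 `Cc1ccc(-c2cc(Nc3nnc(-c4ccc(O)cc4)s3)cs2)cc1` has not yet been measured. It is related to compound 3 by methyl in place of hydrogen on an aromatic carbon, the same change, at the same kind of place, that links the first pair. On the first core that change gave a 1.1-fold higher number from compound 1 to compound 2 (0.04 log units; within the scatter). The step on the second core is expected to be of that size, a 1.1-fold higher number from compound 3 to compound 4 (0.02 log units; within the scatter). Compound 4 is thus estimated at 60000 nM in this assay, with a likely range from 35000 nM to 110000 nM.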

Compound 4, half-maximal inhibitory concentration: 14000 nM
Compound 4: the middle estimate sits 4.3-fold (0.63 log units) above what was measured; the whole stated range lies above it.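

On the second core, methyl in place of hydrogen on an aromatic carbon brings a 4.1-fold lower number from compound 3 to compound 4 (0.61 log units; beyond the scatter) in this assay, whereas on the first core the same change left the number within the scatter, so the step did not carry over from one core to the other: the same change on two cores in this assay, a 1.1-fold higher number (0.04 log units; within the scatter) from compound 1 to compound 2 and a 4.1-fold lower number (0.61 log units; beyond the scatter) from compound 3 to compound 4, 4.5-fold (0.65 log units) apart, beyond the scatter of two such steps
This shows that, across these two pairs, the outcome of going from phenyl to 4-methylphenyl depends on the core that carries it, and that the step read on one core could not be transferred to the other. It does not show which feature of the two cores sets the steps apart or why they differ, and two pairs give no rule for any further core.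

Going by these compounds, whether an ethyl group, a methoxy group or an amine in the same place would move the number further on the second core remains open. So does whether any of these groups would change the number on the first core, where methyl did not.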